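This account rests on a few compounds, and the source may have more. Where it says the series, first, only, none or still open, it means among the compounds named here.

Measured compounds:
compound 1 `COc1ccc(S(=O)(=O)Nc2ccc(C(=O)CSC(C)=O)cn2)cc1` — in a functional assay on U226 cells (Homo sapiens) for cytotoxicity (on this read-out higher numbers stand for an effect only at larger amounts of compound and lower numbers for an effect already at smaller amounts), compound 1 gives "not determined" (no result reported).
compound 2 `CC(=O)SCC(=O)c1ccc(NS(=O)(=O)c2ccc(OCc3ccccn3)cc2)nc1` — in this assay compound 2 gives "not determined" (no result reported).
compound 3 `COCCCOc1ccc(S(=O)(=O)Nc2ccc(C(=O)CSC(C)=O)cn2)cc1` — in this assay compound 3 gives 29000 nM.

All three share one core, and only compound 3 carries a number in this assay; that number is large, so an effect appears only at high amounts of compound 3. Compound 2 stands without a single number, and compound 1 is the one further entry in the same position, so nothing can be said of where compound 2 sits relative to compound 3 or compound 1.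

Compound 4 `CC(=O)SCC(=O)c1ccc(NS(=O)(=O)c2ccc(OCCc3ccccn3)cc2)nc1` is not yet measured. It differs from compound 2 in one place: (pyridin-2-yl)methyl in place of pyridin-2-yl on a saturated chain carbon bound to an oxygen on an aromatic ring. Within the data shown here, no step between two measured compounds describes such a change, so the size of the step in this assay from compound 2 to compound 4 cannot be drawn from the data; the only anchor is compound 3, whose value 29000 nM is weak, and a step of similar weakness, no larger than the usual scatter, is expected. Compound 4 is therefore expected to give about 30000 nM, within a range from 8000 nM to 100000 nM.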

Compound 4, half-maximal effective concentration: 9600 nM
The estimate for compound 4 lay 3.1-fold (0.49 log units) above the measured number; the measured number falls inside the stated range.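

In this assay, placing pyridin-2-yl instead of methoxymethyl on a saturated chain carbon, two bonds along the chain from an oxygen on an aromatic ring, gives a 3.0-fold lower number from compound 3 to compound 4 (0.48 log units; beyond the scatter). Among these compounds, this is the first readable comparison at this position, and it shows that the group carried there can shift the number, though only modestly. Nothing at hand gives a cause for this shift.

From the compounds shown here alone, compound 2 has no number, so the change from (pyridin-2-yl)methoxy to 2-(pyridin-2-yl)ethoxy cannot be read, and the effect of chain length on its own stays unknown. Also open, going by these compounds, is whether a longer chain, such as 3-(pyridin-2-yl)propoxy, or an amine in place of the pyridin-2-yl ring would move the number further.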